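The source may hold more compounds than are shown below. What is called first, only, known or untested is meant among the compounds shown, and "the series" means these compounds.

Among the compounds with values here, compound 1 `N=C(N)c1ccc(-c2ccc(-c3ccc(Cl)cc3)s2)s1` stands lowest of the two numbers measured so far. In a functional assay on K562 cells (Homo sapiens) for inhibition, read by sulforhodamine B assay, with a stated time of 48 h (a lower number here means a stronger inhibitor of growth, a higher number a weaker inhibitor of growth), compound 1 gives 670 nM, and compound 2 `N=C(N)c1ccc(-c2ccc(-c3ccc4ccccc4c3)s2)s1` gives 1530 nM, a gap that lies beyond the scatter of repeated measurements of this kind. Within the data shown here, no step between measured compounds that differ in a single place has been recorded, so the account turns to a compound not yet measured. Compound 3 `N=C(N)c1ccc(-c2ccc(-c3ccc(F)cc3)s2)s1` differs from compound 1 in one place: fluoro in place of chloro on an aromatic carbon. What such a swap does to the number cannot be read from compound 1 and compound 2, which differ in another way. In this assay the expected step is a 1.6-fold higher number from compound 1 to compound 3 (0.22 log units; within the scatter), a small rise that may not clear the scatter. Compound 3 is therefore estimated in this assay at 1100 nM, with a range from 500 nM to 2500 nM, pending its measurement.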

Compound 3, concentration for 50% growth inhibition: 1210 nM
The estimate for compound 3 lay 1.1-fold (0.04 log units) below the measured number; low and high end bracket the measured number.
By their numbers in this assay, from the lowest: compounds 1, 3 and 2 (each within the scatter of the next, the first and the last beyond it).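

In this assay, fluoro in place of chloro on an aromatic carbon, para to a large group, gives a 1.8-fold higher number from compound 1 to compound 3 (0.26 log units; within the scatter). Within the data shown here, this is the first comparison here in which only one place differs, and at this place the chloro and the fluoro cannot be told apart, as the step stays within the scatter. Among these compounds, the single swap therefore shows that this exchange of one heavy atom for another leaves the number of the shared core within the scatter.

On these data alone, it remains open what a group of another kind at the same place would do, such as a methoxy, an amine or a carboxylic acid. Also open, as far as these compounds go, is how the bare ring carrying only hydrogen at that place would compare with compound 1. The data offer no measurement that would explain the size of this step.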